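The source may report more compounds than this note shows. Statements on the series, on what has been measured and on what is new or still open speak of the compounds shown alone.

Measured compounds:
- compound 1 `OC1(CNCc2ccccc2)CCN(CCCc2c[nH]c3ccc(-n4cnnc4)cc23)CC1` — in a functional assay on CHO cells for agonist activity at 5-hydroxytryptamine receptor 1D (Homo sapiens), read by GTPgammaS binding (on this read-out higher numbers stand for an effect only at larger amounts of compound and lower numbers for an effect already at smaller amounts), compound 1 gives 2.2 nM
- compound 2 `CN(Cc1ccccc1)CC1(O)CCN(CCCc2c[nH]c3ccc(-n4cnnc4)cc23)CC1` — in this assay compound 2 gives 3.8 nM

Compound 2 holds the higher of the two numbers, but only by a 1.7-fold higher number from compound 1 to compound 2 (0.24 log units; within the scatter), so the two compounds cannot be told apart in this assay. That step, methyl in place of hydrogen on an amine nitrogen, is the only measured one in the series.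

Compound 3 `Cc1ccccc1CN(C)CC1(O)CCN(CCCc2c[nH]c3ccc(-n4cnnc4)cc23)CC1` differs from compound 2 by methyl in place of hydrogen on an aromatic carbon. Read one bond further out, the change is benzyl to 2-methylbenzyl, with the new group ortho to a large group. For the measured compounds named here, no measured step touches the aromatic ring, so the single step from compound 1 to compound 2 bears on it only indirectly: it shows that a methyl added in this same region of the molecule left this assay unchanged beyond the scatter. With nothing pointing either way, the expected step of a 1.3-fold higher number from compound 2 to compound 3 (0.12 log units; within the scatter) is none beyond the scatter. Compound 3 is therefore estimated at 5 nM in this assay, with a range from 1.5 nM to 20 nM.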

Compound 3, concentration for half-maximal effect: 3.7 nM
Compound 3: the middle estimate sits 1.4-fold (0.13 log units) above what was measured; measured number inside the range.
By their numbers in this assay, from the lowest: compounds 1, 3 and 2 (each within the scatter of the next).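

Working notes on the series: in this assay the aromatic ring of the benzyl group now has its first measured change, and 2-methylbenzyl in place of benzyl, a methyl on an aromatic carbon ortho to a large group, gives a 1.0-fold lower number from compound 2 to compound 3 (0.01 log units; within the scatter) and so leaves the read-out unchanged beyond the scatter. The earlier pair covered only the amine nitrogen; the two methyl groups together, methyl(2-methylbenzyl)amino in place of benzylamino on a saturated chain carbon bound to a saturated ring carbon, give a 1.7-fold higher number from compound 1 to compound 3 (0.23 log units; within the scatter) and also stay within the scatter, so at this level of the read-out this part of the molecule accepts both additions in compound 3. No independent measurement is available that bears on the reason for this flat result.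

Open, from the compounds shown here alone, is whether the tolerance at this aromatic carbon extends beyond methyl, for instance to chlorine, methoxy or trifluoromethyl, or to a methyl on the other carbons of the same ring. Also open, going by these compounds, is whether a larger group on the amine nitrogen, such as ethyl or isopropyl, would stay within the scatter when combined with 2-methylbenzyl.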